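The source may report more compounds than this note shows. Statements on the series, on what has been measured and on what is new or still open speak of the compounds shown alone.

Measured so far in a functional assay on KB cells (Homo sapiens) for cytotoxicity, read by MTT assay, with a stated time of 72 h; a higher number here means a weaker inhibitor, a lower number a stronger inhibitor:
- compound 1 `COc1cccc(/C(=C\c2cn(C(C)=O)c3ccc(OCc4ccccc4)cc23)C(=O)O)c1`: > 100000 nM, a limit of the assay
- compound 2 `CC(=O)n1cc(/C=C(/C(=O)O)c2ccccc2)c2cc(OCc3ccccc3)ccc21`: 55500 nM
- compound 3 `COc1cc(/C(=C\c2cn(C(C)=O)c3ccc(OCc4ccccc4)cc23)C(=O)O)cc(OC)c1OC`: > 100000 nM, a limit of the assay

Compound 3 therefore stands at the limit of this assay; only compound 2 returns a number, and two of the three values sit at the same limit (the limit of > 100000 nM in this assay, at which 2 of the 3 values shown sit).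

Compound 4 `COc1ccccc1/C(=C\c1cn(C(C)=O)c2ccc(OCc3ccccc3)cc12)C(=O)O` has not been measured. It carries 2-methoxyphenyl in place of 3,4,5-trimethoxyphenyl on a double-bonded chain carbon bound to a carbonyl carbon and a double-bonded chain carbon. For the measured compounds named here, three measured steps touch the same place. an at least 1.8-fold higher number from compound 2 to compound 3 (0.25 log units; that floor lies within the scatter); the floor alone is readable, and that floor lies within the scatter. an at least 1.8-fold lower number from compound 1 to compound 2 (0.25 log units; that floor lies within the scatter), again a floor only. a step that the two limits leave unreadable from compound 1 to compound 3, since both ends are limits. Compound 4, like compound 1, keeps a single methoxy on the aryl ring at that place, and compound 1 gives only a limit in this assay; compound 2, with none, gives a number.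

From these floors the expected direction in this assay is downward, an at least 1.1-fold lower number from compound 3 to compound 4 (0.04 log units; that floor lies within the scatter), with a size that the limits do not let one read. In this assay compound 4 is expected to give 90000 nM, with a range from 40000 nM to 200000 nM, and a real chance that only the limit is reported.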

Compound 4, half-maximal inhibitory concentration: > 100000 nM
Compound 4 ended at the assay's limit; the forecaster's own chance of this, stated with the estimate: 55%; middle value at least 1.1-fold (0.04 log units) away from the limit.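

Compound 4, with 2-methoxyphenyl at this place, gives > 100000 nM in this assay, which is a limit of the assay and not a number. For the compounds shown here, the only readable step is an at least 1.8-fold higher number from compound 2 to compound 4 (0.25 log units; that floor lies within the scatter), so this floor alone does not establish a real loss on adding the methoxy; the steps to compound 4 from compound 1 and from compound 3 cannot be read, since both ends of each are limits. The new result extends the limit to a second single-methoxy arrangement, so compound 1, compound 3 and compound 4, the aryl groups carrying methoxy, all end there, while compound 2, with plain phenyl, alone returns a number, and the series now crowds at one end of the scale: the limit of > 100000 nM in this assay, at which 3 of the 4 values shown sit.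

As far as these compounds go, how compound 1, compound 3 and compound 4 rank among themselves stays open, as does whether methoxy itself causes any real loss. Also open, from the compounds shown here alone, is whether a hydroxyl, a fluorine or an amine on the phenyl ring at this place would give a value inside the range of the assay.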